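A few compounds are considered here, and "the series" means these few. Any claim that something is new, unique, unknown or untested is made for them only; others in the source may bear on it.

Measured so far in a functional assay on MIA PaCa-2 cells (Homo sapiens) for inhibition, read by MTT assay, with a stated time of 72 h; on this read-out higher numbers stand for weaker inhibition of growth and lower numbers for stronger inhibition of growth:
compound 1, `COc1ccc(CNCCCNS(=O)(=O)c2cc(C(F)(F)F)cc(C(F)(F)F)c2)cc1OC`: 2800 nM
compound 2, `O=S(=O)(NCCCCCCNCc1ccc(Br)cc1)c1ccc(C(F)(F)F)cc1`: 3830 nM
compound 3, `O=S(=O)(NCCCCCCNCc1ccc(Br)cc1)c1cc(Cl)cc(Cl)c1`: 12000 nM

Compound 1 has the lowest number of the three. The number for compound 2 lies within the scatter of it, so no order between compounds 1 and 2 can be read. Compound 3 stands a step beyond the scatter higher than compound 1.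

Compound 4, `COc1ccccc1CNCCCNS(=O)(=O)c1cc(C(F)(F)F)cc(C(F)(F)F)c1`, is not yet measured. It differs from compound 1 in one place: 2-methoxyphenyl in place of 3,4-dimethoxyphenyl on a saturated chain carbon bound to an amine nitrogen. For the measured compounds named here, no measured pair shows what such a change does on the shared core, so the expectation rests on the run of compound 1 alone. In this assay the step from compound 1 to compound 4 is expected to be small, a 1.3-fold higher number from compound 1 to compound 4 (0.10 log units; within the scatter), with no direction beyond the scatter. Compound 4 is estimated at 3500 nM, within 1200 nM to 10000 nM.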

Compound 4, concentration for 50% growth inhibition: 3100 nM
The estimate for compound 4 lay 1.1-fold (0.05 log units) above the measured number, within the range that was stated.
By their numbers in this assay, from the lowest: compounds 1, 4 and 2 (each within the scatter of the next); then compound 3.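

In this assay, for the compounds shown here, 2-methoxyphenyl in place of 3,4-dimethoxyphenyl on a saturated chain carbon bound to an amine nitrogen gives a 1.1-fold higher number from compound 1 to compound 4 (0.04 log units; within the scatter), the first single-place comparison on the shared core. At this place, the read-out does not separate 3,4-dimethoxybenzyl from 2-methoxybenzyl. No available evidence bears on this result.

Open, on these data alone, is whether an unsubstituted phenyl at this place would read the same. Also open, as far as these compounds go, is what an amine or a carboxylic acid on the aromatic ring would do to growth inhibition on the shared core.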